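The source may hold more compounds than are shown below. What is called first, only, known or untested is meant among the compounds shown, and "the series" means these compounds.

In a functional assay on DU-145 cells (Homo sapiens) for antiproliferative activity, read by WST assay, with a stated time of 3 days (a higher number here means a weaker inhibitor, a lower number a stronger inhibitor), compound 1 `CCCOc1c(-c2cc(OC)c(OC)c(OC)c2)oc2ccccc2c1=O` gives 2800 nM and compound 2 `CCCN(CCC)CCCCOc1c(-c2cc(OC)c(OC)c(OC)c2)oc2ccccc2c1=O` gives 35800 nM, the higher of the two numbers. Compound 3 `CCCCCN(CCCCC)CCCCOc1c(-c2cc(OC)c(OC)c(OC)c2)oc2ccccc2c1=O` differs from compound 2 by dipentylamino in place of dipropylamino on a saturated chain carbon, four bonds along the chain from an oxygen on an aromatic ring. Among the compounds with values here, only one measured step bears on this change, the large 13-fold higher number from compound 1 to compound 2 (1.11 log units; beyond the scatter). That step adds (dipropylamino)methyl in place of hydrogen, so it touches the same chain but does not size a change from dipropylamino to dipentylamino, and no such change has been measured. A moderate shift toward a lower number in this assay is therefore expected, estimated as a 2.0-fold lower number from compound 2 to compound 3 (0.30 log units; within the scatter), with a return to the level of compound 1 not anticipated. For compound 3 the expected value is 18000 nM, with an estimated range of 5000 nM to 50000 nM.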

Compound 3, half-maximal inhibitory concentration: 12500 nM
For compound 3 the middle estimate is 1.4-fold (0.16 log units) above the measured one; low and high end bracket the measured number.
By their numbers in this assay, from the lowest: compound 1; then compound 3; then compound 2.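

In this assay, within the data shown here, dipentylamino in place of dipropylamino gives a 2.9-fold lower number from compound 2 to compound 3 (0.46 log units; beyond the scatter) and so shows that the number responds to the groups on this amine, which the single earlier step could not size. Even so, (dipentylamino)methyl in place of hydrogen still gives a 4.5-fold higher number from compound 1 to compound 3 (0.65 log units; beyond the scatter) and thus recovers only part of the rise seen with the dipropylamino chain. Nothing available explains either step.

As far as these compounds go, with only two amines compared, it remains open whether the number would keep falling with a longer chain on the nitrogen, such as dioctylamino, or would turn back up. From the compounds shown here alone, how a ring amine such as piperidine, a primary amine or a carboxylic acid at this place would compare with the hydrogen of compound 1 also stays open.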